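Aryl-acetamide piperazine series: benzyl to pyridin-4-ylmethyl on compound 1

The source may report more compounds than this note shows. Statements on the series, on what has been measured and on what is new or still open speak of the compounds shown alone.

Measured compounds:
- compound 1 `O=C(CN1CCN(c2nnc(Cc3ccccc3)c3ccccc23)CC1)Nc1c(F)cccc1F`: 84500 nM
- compound 2 `COc1ccc(NC(=O)CN2CCN(c3nnc(Cc4ccccc4)c4ccccc34)CC2)cc1OC`: "not active" (no number reported)
- compound 3 `Cc1cccc(Cl)c1NC(=O)CN1CCN(c2nnc(Cc3ccccc3)c3ccccc23)CC1`: 7420 nM

Compound 1 gives 84500 nM in a functional assay on A549 cells (Homo sapiens) for cytotoxicity, read by MTT assay, with a stated time of 72 h (on this read-out lower numbers stand for stronger inhibition and higher numbers for weaker inhibition), and stands as the higher of the two numbers in hand; compound 3 lies at 7420 nM, and compound 2 is reported without a number. Within the data shown here, the one step within the measured set, an 11-fold lower number from compound 1 to compound 3 (1.06 log units; beyond the scatter), concerns the aryl group on the amide-type nitrogen and leaves the benzyl end of the core untouched.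

Compound 4 `O=C(CN1CCN(c2nnc(Cc3ccncc3)c3ccccc23)CC1)Nc1c(F)cccc1F` is not yet measured. It differs from compound 1 by pyridin-4-yl in place of phenyl on a saturated chain carbon bound to an aromatic carbon. Among the measured compounds shown here, no measured pair in this set varies that position, so no step bears directly on the change; the amide-side step from compound 1 to compound 3 speaks only to the other end of the core. With nothing to anchor a direction, the expectation for compound 4 is a step of a 1.1-fold higher number from compound 1 to compound 4 (0.03 log units; within the scatter), that is none beyond the scatter. Compound 4 is therefore estimated at 90000 nM, with a range from 30000 nM to 270000 nM; given compound 2 at "not active" (no number reported), a report without a number is also possible.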

Compound 4, half-maximal inhibitory concentration: 54400 nM
Beside the measured number, compound 4's estimate is 1.7-fold (0.22 log units) above it, within the range that was stated.
By their numbers in this assay, from the lowest: compound 3; then compounds 4 and 1 (each within the scatter of the next).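

In this assay the benzyl end of the shared core now has a measured step: pyridin-4-yl in place of phenyl on a saturated chain carbon bound to an aromatic carbon gives a 1.6-fold lower number from compound 1 to compound 4 (0.19 log units; within the scatter) and so stays inside the usual scatter. Among these compounds, the earlier step at the amide end lay beyond the scatter, so this is the first sign that a change can leave the read-out unresolved, even with a ring nitrogen and one hydrogen-bond acceptor entering. No measured evidence accounts for this result.

Open, as far as these compounds go, is how a pyridin-3-yl group, a longer chain to the ring, or an amine or carboxylic acid on the ring would read at this position. Also open, from the compounds shown here alone, is whether pyridin-4-yl reads the same with the 2-chloro-6-methylphenyl amide of compound 3.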